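Moving the Methoxy Group on a Sulfonamide Benzoxazole

This account rests on a few compounds, and the source may have more. Where it says the series, first, only, none or still open, it means among the compounds named here.

Three sulfonamides have been tested in an assay on cells for inhibition of HSP60/HSP10 (Homo sapiens), with a stated time of 60 min; on this read-out lower numbers stand for stronger inhibition and higher numbers for weaker inhibition. Compound 1 `N#Cc1ccc(S(=O)(=O)Nc2ccc(-c3nc4cc(NS(=O)(=O)c5ccc(C#N)cc5)ccc4o3)cc2)cc1` gives 49000 nM there. For compound 2 `COc1ccc(S(=O)(=O)Nc2ccc(-c3nc4ccccc4o3)cc2)cc1` the assay reports only a limit, > 100000 nM. Compound 3 `Cc1ccccc1S(=O)(=O)Nc1ccc2oc(-c3ccccc3)nc2c1` likewise reaches only a limit, > 100000 nM. Compound 2 thus stands at the limit of > 100000 nM in this assay, at which 2 of the 3 values shown sit, and has no measured number of its own.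

Compound 4 `COc1cccc(S(=O)(=O)Nc2ccc(-c3nc4ccccc4o3)cc2)c1` has not yet been measured in this assay. It is obtained from compound 2 by the change (3-methoxyphenyl in place of 4-methoxyphenyl on a sulfonyl sulfur), so the same atoms are joined differently. Going by the values given here, no step between measured compounds is available to show how large such a change tends to be, and no other pair in this set differs in the same way. Because compound 2 sits at the limit of > 100000 nM in this assay, at which 2 of the 3 values shown sit, the step to compound 4 can hardly be expected to move beyond the usual scatter in either direction. The expected step of a number no higher from compound 2 to compound 4 (the limit leaves the size open) is therefore essentially none. Compound 4 is estimated at 100000 nM in this assay, within a range from 30000 nM to 300000 nM, and a further limit rather than a number is quite possible.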

Compound 4, half-maximal inhibitory concentration: 80000 nM
Beside the measured number, compound 4's estimate is 1.3-fold (0.10 log units) above it, and the stated range covers the measured number.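

Moving the methoxy group on the ring at the sulfonyl sulfur gives the first step in this set that can be read at this position: in this assay, 3-methoxyphenyl in place of 4-methoxyphenyl gives an at least 1.2-fold lower number from compound 2 to compound 4 (0.09 log units; that floor lies within the scatter). Compound 4 therefore has a measured number where compound 2 has none, but the floor of the step does not show a real gain. Going by these compounds, the true size of the step stays open because compound 2 has only a limit: the limit of > 100000 nM in this assay, at which 2 of the 4 values shown sit.

The compounds shown leave open how an amine or a carboxylic acid in place of the methoxy group on this ring would read in this assay. They also leave open whether the same move of the methoxy group would give a similar step on the core of compound 1.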